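Swapping the Ketone Side Chain for an Ester

The source may hold more compounds than are shown below. What is called first, only, known or untested is meant among the compounds shown, and "the series" means these compounds.

Of the compounds shown here, three sharing one core have been tested in an assay on membranes from CHO cells for displacement of a labelled ligand from adenosine receptor A1 (Homo sapiens), read by scintillation counting, with a stated time of 60 min, tested at 1 uM; on this read-out higher numbers stand for more inhibition at the one concentration tested (going by the name of the read-out) and lower numbers for less inhibition. Compound 1 `CC1=C(C(=O)CC(C)C)C(c2ccco2)NC(=O)N1` gives 16%. Compound 2 `CC1=C(C(=O)CC(C)C)C(c2ccoc2)NC(=O)N1` gives 23%, and compound 3 `CC1=C(C(=O)CC(C)C)C(c2cccs2)NC(=O)N1` gives 19%. The three numbers sit within the usual scatter of one another, so compound 1 cannot be placed apart from the other two on this read-out. The known steps confirm this: a number 7 percentage points higher from compound 1 to compound 2 (within the scatter), a number 3 percentage points higher from compound 1 to compound 3 (within the scatter), and a number 4 percentage points lower from compound 2 to compound 3 (within the scatter).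

Compound 4 `CCC(CC)OC(=O)C1=C(C)NC(=O)NC1c1ccco1` is not yet measured. It differs from compound 1 in one place: (pentan-3-yl)oxy in place of isobutyl on a carbonyl carbon. The measured steps all change the group on a saturated ring carbon, not the carbonyl carbon, so none of them bears directly on this change; they only show that small variations on the core left this assay essentially unchanged. Going by the values given here, with no direct precedent, the expected step is a number 2 percentage points higher from compound 1 to compound 4 (within the scatter), that is, nothing beyond the scatter, though with wide uncertainty. Compound 4 is therefore estimated at 18%, with a range from 4% to 36%.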

Compound 4, a percentage reported as inhibition, at one concentration (the size of the read-out at that concentration, not a potency): 2%
Compound 4: middle estimate off by 16 percentage points, on the high side, outside the stated range (below it).
By their numbers in this assay, from the lowest: compound 4; then compounds 1, 3 and 2 (each within the scatter of the next).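

The carbonyl carbon turns out to be a position that registers in this assay: (pentan-3-yl)oxy in place of isobutyl gives a number 14 percentage points lower from compound 1 to compound 4 (beyond the scatter), the only step shown that leaves the scatter. The earlier swaps among furan-2-yl, furan-3-yl and thiophen-2-yl on the saturated ring carbon all stayed within the scatter, so of the two places varied, only this one has shown a clear change. Nothing at hand accounts for the lower number.

This single change brings in an oxygen on the carbonyl carbon and a different carbon chain together, so the compounds shown cannot say which of the two goes with the drop. Open too, on these data alone, is how a smaller group such as methoxy or ethoxy, or an amine forming an amide, would read at this carbon.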